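The source may report more compounds than this note shows. Statements on the series, on what has been measured and on what is new or still open speak of the compounds shown alone.

Among the compounds with values here, in a functional assay on HCT-15 cells (Homo sapiens) for cytotoxicity, read by ELISA, with a stated time of 2 days (on this read-out lower numbers stand for stronger inhibition and higher numbers for weaker inhibition), three compounds have numbers so far. Compound 1 `Oc1ccc(-c2cc(-c3ccccc3)cc(-c3ccsc3)n2)cc1` gives 1100 nM, compound 2 `Oc1ccc(-c2cc(-c3ccccc3)cc(-c3ccc(O)cc3)n2)cc1` gives 3000 nM, and compound 3 `Oc1cccc(-c2cc(-c3ccccc3)nc(-c3ccsc3)c2)c1` gives 24600 nM, the highest number of the three and so the weakest inhibition. The next structure, compound 4 `Oc1cccc(-c2cc(-c3ccccc3)nc(-c3ccncc3)c2)c1`, keeps the rest of compound 3 and changes one group: pyridin-4-yl in place of thiophen-3-yl on an aromatic carbon. Here pyridin-4-yl takes the place of thiophen-3-yl on an aromatic carbon. Within the data shown here, only one measured step bears on this swap. In it, 4-hydroxyphenyl replaced thiophen-3-yl, giving a 2.7-fold higher number from compound 1 to compound 2 (0.44 log units; beyond the scatter). That step is only a loose guide, since its incoming group is not pyridin-4-yl and its core is arranged differently from that of compound 3. A small rise in the number is therefore expected in this assay, perhaps none beyond the scatter. The expected change is a 1.6-fold higher number from compound 3 to compound 4 (0.21 log units; within the scatter). For compound 4, the estimated value is 40000 nM, with an expected range of 13000 nM to 100000 nM.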

Compound 4, half-maximal inhibitory concentration: 18700 nM
Beside the measured number, compound 4's estimate is 2.1-fold (0.33 log units) above it; measured number inside the range.
By their numbers in this assay, from the lowest: compound 1; then compound 2; then compounds 4 and 3 (each within the scatter of the next).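

In this assay, a 1.3-fold lower number from compound 3 to compound 4 (0.12 log units; within the scatter) when pyridin-4-yl takes the place of thiophen-3-yl on the aromatic carbon next to the ring nitrogen, so this swap of one aromatic ring for another has no effect that can be told from the scatter. Within the data shown here, the only earlier change at a comparable place, a 2.7-fold higher number from compound 1 to compound 2 (0.44 log units; beyond the scatter) on a differently arranged core, did go beyond the scatter, and the new step shows that a replacement here need not do so. No measurement is at hand to explain this result.

Still open, on these data alone, is whether the same swap would behave alike on the core of compound 1. Also open, as far as these compounds go, is how this position would respond to a group without an aromatic ring, such as an amine or a carboxylic acid.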